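This account rests on a few compounds, and the source may have more. Where it says the series, first, only, none or still open, it means among the compounds named here.

Measured so far:
Compound 1, `CN(C)C1(Cc2ccccc2)CCN(c2cc(C(F)(F)F)ccc2CNC(=O)NCc2ccc(NS(C)(=O)=O)c(F)c2)CC1`, gives 266 nM in an assay on CHO cells for displacement of a labelled ligand from transient receptor potential cation channel subfamily V member 1 (Homo sapiens), read by scintillation counting, with a stated time of 60 min; on this read-out higher numbers stand for weaker inhibition and lower numbers for stronger inhibition.
Compound 2, `CN(C)C1(Cc2ccccc2)CCN(c2cc(C(F)(F)F)ccc2CNC(=O)Nc2cccc3[nH]c(=O)ccc23)CC1`, gives 1.67 nM in this assay.

Of these two numbers, compound 2 holds the lower one, and the gap that separates it from compound 1 lies far beyond the usual scatter of repeated measurements, so compound 2 is the more potent of the two on this read-out.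

Compound 3, `CN(C)C1(Cc2ccccc2)CCN(c2cc(C(F)(F)F)ccc2CNC(=O)Nc2ccc3cnccc3c2)CC1`, has not yet been measured. It differs from compound 2 in a single place: a group of 10 heavy atoms (9 carbon, 1 nitrogen; one six-membered aromatic ring of carbon only, one six-membered aromatic ring with 1 hetero atom) in place of a group of 11 heavy atoms (9 carbon, 1 nitrogen, 1 oxygen; one six-membered aromatic ring of carbon only, one six-membered aromatic ring with 1 hetero atom), on an amide-type nitrogen. The two ring systems are of similar size, but the hydrogen-bond donor and the carbonyl-type oxygen of the group that leaves are absent from the group that enters.

Among the compounds with values here, no measured pair in this set isolates a change of this kind, so the expectation rests on the general observation that removing a donor from this part of compound 2 more often weakens than strengthens binding. Compound 3 is therefore expected to remain fairly potent, with an expected moderate step toward a higher number of a 4.8-fold higher number from compound 2 to compound 3 (0.68 log units; beyond the scatter). The estimate for compound 3 in this assay is 8 nM, within a range from 2 nM to 40 nM.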

Compound 3, inhibition constant: 62 nM
Estimate against measurement, compound 3: 7.8-fold (0.89 log units) below; measured number above the stated range.
By their numbers in this assay, from the lowest: compound 2; then compound 3; then compound 1.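

In this assay, placing isoquinolin-6-yl on the amide-type nitrogen gives a 37-fold higher number from compound 2 to compound 3 (1.57 log units; beyond the scatter), which shows that binding here depends strongly on which two-ring aromatic group sits at this position. The two groups have the same ring types and nearly the same size, so that resemblance alone does not preserve the potency of compound 2, yet the group that leaves has a hydrogen-bond donor, an oxygen and a double bond outside aromatic rings, none of which isoquinolin-6-yl has. No measurement explains the loss or shows which of these differences matters most.

On these data alone, because these features change together, the contribution of each remains open, and a pair that removes only the donor, such as a group with a methyl on the ring nitrogen of the group that leaves, could separate it from the oxygen. As far as these compounds go, it also remains open whether other two-ring groups at this position, such as indazol-5-yl or quinolin-5-yl, would stay closer to compound 2 or to compound 3.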